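The compounds below may be only part of what the source reports. "The series", "measured", "known", "first", "only" and "open" are said of these compounds alone.

Compound 1 `CSc1cnc(OCCOc2ncnc(NS(=O)(=O)c3ccc(C(C)(C)C)cc3)c2-c2ccc(Cl)cc2)nc1` carries a 4-chlorophenyl group on an aromatic carbon of the shared core. In an assay on cells (Endothelial cell) for binding affinity to Endothelin-1 receptor (Sus scrofa) (on this read-out higher numbers stand for weaker inhibition and lower numbers for stronger inhibition), compound 1 reaches only the limit of < 0.001 nM, which is not a number. Among the compounds with values here, compound 2 `CSc1cnc(OCCOc2ncnc(NS(=O)(=O)c3ccc(C(C)(C)C)cc3)c2-c2ccc(C)s2)nc1` gives 0.16 nM in this assay, the only plain number among the two values shown. Within the data shown here, the single measured step, an at least 160-fold higher number from compound 1 to compound 2 (2.20 log units; beyond the scatter), shows that exchanging the group on that aromatic carbon can shift the number greatly. Compound 3 `CSc1cnc(OCCOc2ncnc(NS(=O)(=O)c3ccc(C(C)(C)C)cc3)c2-c2ccco2)nc1` differs from compound 2 by furan-2-yl in place of 5-methylthiophen-2-yl on an aromatic carbon. Given that sole step, compound 3 is expected to move a 3.1-fold higher number from compound 2 to compound 3 (0.49 log units; beyond the scatter), a modest weakening. The estimate for compound 3 is 0.5 nM, within 0.1 nM to 3 nM.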

Compound 3, half-maximal inhibitory concentration: 2.9 nM
Compound 3: the middle estimate sits 5.8-fold (0.76 log units) below what was measured, within the range that was stated.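

The position remains sensitive even when one five-membered aromatic ring with one hetero atom replaces another, with an 18-fold higher number from compound 2 to compound 3 (1.26 log units; beyond the scatter). Furan-2-yl also falls far short of 4-chlorophenyl, with an at least 2900-fold higher number from compound 1 to compound 3 (3.46 log units; beyond the scatter). Compound 1 stands at a limit, not a number: the limit of < 0.001 nM in this assay, at which 1 of the 3 values shown sits.

From the compounds shown here alone, this swap exchanges sulfur for oxygen and removes the methyl group in one step, so the share of each remains unknown; thiophen-2-yl or 5-methylfuran-2-yl would separate them. Going by these compounds, how an amine or a saturated ring such as cyclohexyl would fare at this carbon also remains open.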